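Swapping methoxy for fluoro on the aryl group

The compounds below may be only part of what the source reports. "The series", "measured", "known", "first", "only" and "open" are said of these compounds alone.

Compound 3 `COc1ccc(-n2nc(C(=O)NCC(=O)Nc3nc4ccc(OC)cc4s3)c3ccccc3c2=O)cc1` gives 60 nM in an assay on L cells for inhibition of Protein-serine O-palmitoleoyltransferase porcupine (Mus musculus), read by reporter gene assay, with a stated time of 24 h (a lower number here means that less compound is needed, a higher number that more compound is needed for the effect), the lowest of the two numbers shown. Its nearest measured neighbour is compound 1 `COc1ccc(-n2nc(C(=O)NCC(=O)Nc3nc4ccccc4s3)c3ccccc3c2=O)cc1`, which in this assay gives 25000 nM; the step of a 420-fold lower number from compound 1 to compound 3 (2.62 log units; beyond the scatter) comes from a methoxy in place of hydrogen on an aromatic carbon. Compound 2 `O=C(CNC(=O)c1nn(-c2ccc(F)cc2)c(=O)c2ccccc12)Nc1nc2ccccc2s1` in this assay reaches only > 25000 nM, which is a limit of the assay and not a number. Compound 4 `COc1ccc2nc(NC(=O)CNC(=O)c3nn(-c4ccc(F)cc4)c(=O)c4ccccc34)sc2c1` is not yet measured; it differs from compound 3 as follows: fluoro in place of methoxy on an aromatic carbon. The same change, fluoro in place of methoxy on an aromatic carbon, has been measured once, in the step of a number no lower from compound 1 to compound 2 (the limit leaves the size open), where the number went no lower and the second compound ended at the limit of > 25000 nM in this assay, at which 1 of the 3 values shown sits. Nothing here suggests that a fluoro in this place gives a lower number than a methoxy. The step of a 10-fold higher number from compound 3 to compound 4 (1.00 log units; beyond the scatter) is therefore expected to raise the number. Compound 4 is estimated at 600 nM, with a range from 150 nM to 5000 nM.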

Compound 4, half-maximal effective concentration: 90 nM
The estimate for compound 4 lay 6.7-fold (0.82 log units) above the measured number; measured number outside the range, below it.
By their numbers in this assay, from the lowest: compounds 3 and 4 (each within the scatter of the next); then compound 1.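

In this assay, the change from 4-methoxyphenyl to 4-fluorophenyl now has a readable size, a 1.5-fold higher number from compound 3 to compound 4 (0.18 log units; within the scatter), so where the second methoxy is present, the low number does not depend on the 4-methoxyphenyl group. Going by these compounds alone, that second methoxy, in place of hydrogen on an aromatic carbon, also gives an at least 270-fold lower number from compound 2 to compound 4 (2.44 log units; beyond the scatter), so the large effect of this change is no longer seen only with the 4-methoxyphenyl group. The two steps for this change are both large, but how closely they agree cannot be settled: the same change on two cores in this assay, a 420-fold lower number (2.62 log units; beyond the scatter) from compound 1 to compound 3 and an at least 270-fold lower number (2.44 log units; beyond the scatter) from compound 2 to compound 4; the limit leaves it open whether they differ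

As far as these compounds go, compound 2 gives > 25000 nM, which is a limit, so the size of the fluoro change on the core of compound 1 cannot be read: the same change on two cores in this assay, a number no lower (the limit leaves the size open) from compound 1 to compound 2 and a 1.5-fold higher number (0.18 log units; within the scatter) from compound 3 to compound 4; the limit leaves it open whether they differ Also open is whether an amine or a carboxylic acid in place of the fluoro of compound 4 would keep the number in this range.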